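A few compounds are considered here, and "the series" means these few. Any claim that something is new, unique, unknown or untested is made for them only; others in the source may bear on it.

Four related compounds are compared in an ADME assay (liver) for metabolic stability, with Liver microsome (Rattus norvegicus) as the target, using microsomes and NADPH, with a stated time of 30 min, at 37 degrees C, tested at 1 uM; on this read-out higher numbers stand for fast clearance and lower numbers for slow clearance. Compound 1 `Nc1ccc(S(=O)(=O)c2ccc(-c3ncc(C(O)(C(F)(F)F)C(F)(F)F)cc3Cl)cc2)cn1` gives 18 mL.min-1.g-1 in this assay, and compound 2 `CC#Cc1cc(C(O)(C(F)(F)F)C(F)(F)F)cnc1-c1ccc(S(=O)(=O)c2ccc(N)nc2)cc1` gives 177 mL.min-1.g-1; the change between them is prop-1-yn-1-yl in place of chloro on an aromatic carbon, and it produced a 9.8-fold higher number from compound 1 to compound 2 (0.99 log units; beyond the scatter). Compound 3 `CC(O)(c1cnc(-c2ccc(S(=O)(=O)c3ccc(N)nc3)s2)c(Cl)c1)C(F)(F)F` has a different core, and how the two cores differ is not broken down here. For compound 3 this assay reports only a limit, < 14 mL.min-1.g-1, which is the limit of < 14 mL.min-1.g-1 in this assay, at which 1 of the 3 values shown sits. Compound 4 `CC#Cc1cc(C(C)(O)C(F)(F)F)cnc1-c1ccc(S(=O)(=O)c2ccc(N)nc2)s1` carries the same kind of change, (prop-1-yn-1-yl in place of chloro on an aromatic carbon), though here the place is meta to a 1-hydroxy-1-(trifluoromethyl)ethyl group rather than to a 2,2,2-trifluoro-1-hydroxy-1-(trifluoromethyl)ethyl group. From compound 3 to compound 4 a step of about an at least 4.2-fold higher number from compound 3 to compound 4 (0.63 log units; beyond the scatter) is expected in this assay, resting on a 9.8-fold higher number from compound 1 to compound 2 (0.99 log units; beyond the scatter). Compound 4 is therefore estimated at 60 mL.min-1.g-1, with an expected range from 20 mL.min-1.g-1 to 180 mL.min-1.g-1.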

Compound 4, intrinsic clearance in microsomes: > 399 mL.min-1.g-1
Compound 4 gave a limit, no number (the forecaster's own chance of this, stated with the estimate: 10%); at least 6.6-fold (0.82 log units) between middle value and limit.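

In this assay, putting prop-1-yn-1-yl in place of chloro gives a higher number on both cores, and on the core of compound 3 it gives an at least 28-fold higher number from compound 3 to compound 4 (1.45 log units; beyond the scatter). The direction of the change carries from one core to the other, but its size does not: the same change on two cores in this assay, a 9.8-fold higher number (0.99 log units; beyond the scatter) from compound 1 to compound 2 and an at least 28-fold higher number (1.45 log units; beyond the scatter) from compound 3 to compound 4, at least 2.8-fold (0.46 log units) apart, beyond the scatter of two such steps

Compound 3 and compound 4 both gave limits of the assay and not numbers; the true size of their step stays unknown, and these pairs do not show which part of the cores accounts for the gap.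

Open, on these data alone, is how a nitrile or an ethyl group at this place would compare with chloro and prop-1-yn-1-yl in this assay.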